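Swapping Isopropyl for Cyclopentyl at the Ketone Side Chain

The compounds below may be only part of what the source reports. "The series", "measured", "known", "first", "only" and "open" are said of these compounds alone.

Compound 3 `Cc1ccc(C(=O)O)cc1OCCCCOc1ccc(C(=O)CC(C)C)c(O)c1C` gives only a limit: in an assay on HEK293 cells for positive allosteric modulation of metabotropic glutamate receptor 3 (Rattus norvegicus), read by thallium flux, with a stated time of 2.5 min (a lower number here means that less compound is needed, a higher number that more compound is needed for the effect), compound 3 shows > 10000 nM. Compound 1 `Cc1c(OCCCCOc2ccc(C(=O)O)cc2Cl)ccc(C(=O)CC2CCCC2)c1O` likewise gives only a limit, > 10000 nM. Both belong to the limit of > 10000 nM in this assay, at which 2 of the 3 values shown sit. Compound 2 `Cc1c(OCCCCOc2cccc(C(=O)O)c2)ccc(C(=O)CC2CCCC2)c1O` gives a number, 3400 nM. For the measured compounds named here, the one measured step, an at least 2.9-fold lower number from compound 1 to compound 2 (0.46 log units; beyond the scatter), changes the carboxyphenyl end of the molecule, not the ketone side chain, so it does not bear on the change now in question. Compound 4 `Cc1ccc(C(=O)O)cc1OCCCCOc1ccc(C(=O)CC2CCCC2)c(O)c1C` differs from compound 3 by cyclopentyl in place of isopropyl on a saturated chain carbon bound to a carbonyl carbon. Compounds 1 and 2 already carry the cyclopentyl group, and compound 2 gives a measurable number, so compound 4 is expected to give 5000 nM, within 1500 nM to 20000 nM. The expected step is an at least 2.0-fold lower number from compound 3 to compound 4 (0.30 log units; that floor lies within the scatter), though a second limit would not be surprising.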

Compound 4, half-maximal effective concentration: > 10000 nM
Compound 4 was reported as a limit; the forecaster's own chance of this, stated with the estimate: 40%; middle value at least 2.0-fold (0.30 log units) away from the limit.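

In this assay compound 4 gives > 10000 nM, which is a limit and not a number. Cyclopentyl on a saturated chain carbon bound to a carbonyl carbon therefore does not by itself give a readable number, and methyl in place of hydrogen on an aromatic carbon carries an at least 2.9-fold higher number from compound 2 to compound 4 (0.46 log units; beyond the scatter). The steps to compound 4 from compound 3 and from compound 1 cannot be read, because each joins two limits: the limit of > 10000 nM in this assay, at which 3 of the 4 values shown sit.

From the compounds shown here alone, whether isopropyl in place of cyclopentyl would change the number of compound 2 remains open. So does the effect of a fluorine or an ethyl group in place of that methyl.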